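A Fluoro Swap at a New Aromatic Carbon

The source may report more compounds than this note shows. Statements on the series, on what has been measured and on what is new or still open speak of the compounds shown alone.

- Compound 1 `O=C1CCCCC/C1=C\c1ccccc1` gives 215000 nM
- Compound 2 `O=C1CCCCC/C1=C\c1cccc(F)c1` gives 482000 nM

Among the compounds with values here, in a functional assay on MOLT-4 cells (Homo sapiens) for inhibition (on this read-out lower numbers stand for stronger inhibition and higher numbers for weaker inhibition), compound 1 gives 215000 nM as the lower of the two numbers so far, which makes it the stronger inhibitor of the pair. Compound 3 `O=C1CCCCC/C1=C\c1ccc(F)cc1` carries a single change from compound 1, described as fluoro in place of hydrogen on an aromatic carbon with the rest of the structure kept. Within the data shown here, one measured step bears on this change, the same kind of swap at a different aromatic carbon. That step was modest, a 2.2-fold higher number from compound 1 to compound 2 (0.35 log units; beyond the scatter) in the same read-out. One step is thin evidence for a new position, so a similarly modest rise, meaning weaker inhibition, is expected, although a change within the scatter remains possible. The estimate for this change is a 1.6-fold higher number from compound 1 to compound 3 (0.20 log units; within the scatter) as an expected step. For compound 3 the expected value is 340000 nM with an estimated range from 140000 nM to 750000 nM in this assay.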

Compound 3, half-maximal inhibitory concentration: 250000 nM
For compound 3 the middle estimate is 1.4-fold (0.13 log units) above the measured one; low and high end bracket the measured number.
By their numbers in this assay, from the lowest: compounds 1, 3 and 2 (each within the scatter of the next, the first and the last beyond it).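

In this assay, putting fluoro on the aromatic carbon para to a group of 9 heavy atoms gives a 1.2-fold higher number from compound 1 to compound 3 (0.07 log units; within the scatter) and so, at this position, produces no change that can be told apart from the scatter. The same kind of swap at a different aromatic carbon gave a 2.2-fold higher number from compound 1 to compound 2 (0.35 log units; beyond the scatter) and went beyond the scatter, so among these compounds a fluoro swap does not have the same outcome at every aromatic carbon. No measurement shown here explains why the two positions differ.

On these data alone, whether a chlorine atom, a methoxy group or an amine on this same carbon would move the number beyond the scatter remains open. Also open, as far as these compounds go, is how fluoro would behave on any other aromatic carbon of this ring.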